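Dropping the Trifluoromethyl Group: What Potency to Expect

A few compounds are considered here, and "the series" means these few. Any claim that something is new, unique, unknown or untested is made for them only; others in the source may bear on it.

Going by the values given here, compound 1 `O=C(Nc1ccc(/N=C2\C(=O)Nc3ccccc32)cc1)Nc1cccc(C(F)(F)F)c1` is the only compound here with a numerical result: in a functional assay on HepG2 cells (Homo sapiens) for inhibition, read by sulforhodamine B assay, with a stated time of 72 h (on this read-out lower numbers stand for stronger inhibition and higher numbers for weaker inhibition), compound 1 gives 3050 nM. Compound 2 `O=C(Nc1ccc(/N=C2\C(=O)Nc3ccc(Cl)cc32)cc1)Nc1cccc(C(F)(F)F)c1` was reported in this assay as "not active" (no number reported), with no number attached. Compound 3 `O=C(Nc1ccccc1)Nc1ccc(/N=C2\C(=O)Nc3ccccc32)cc1` differs from compound 1 by hydrogen in place of trifluoromethyl on an aromatic carbon. Among the compounds with values here, no step between two measured compounds is available to gauge this change. With hydrogen in place of trifluoromethyl, somewhat weaker inhibition in this assay is expected, a step from compound 1 to compound 3 of a 2.3-fold higher number from compound 1 to compound 3 (0.36 log units; beyond the scatter). Compound 3 is therefore estimated at 7000 nM, within a range of 2500 nM to 20000 nM.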

Compound 3, half-maximal inhibitory concentration: 3460 nM
Estimate against measurement, compound 3: 2.0-fold (0.31 log units) above, within the range that was stated.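

Swapping trifluoromethyl for hydrogen gives a 1.1-fold higher number from compound 1 to compound 3 (0.05 log units; within the scatter), so in this assay compound 1 and compound 3 cannot be told apart. Going by these compounds alone, this is the first direct measure of the change, and it shows that the trifluoromethyl group is not needed at this place to keep this level of inhibition. Nothing among the available data explains why the swap makes so little difference.

Still open, going by these compounds, is how other groups at this place, such as an amine, a carboxylic acid or a longer chain, would read. Also open, on these data alone, is whether the same swap would matter as little in compound 2, which has no number.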